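Removing One Methoxy Group from a Weakly Active Chalcone

The source may report more compounds than this note shows. Statements on the series, on what has been measured and on what is new or still open speak of the compounds shown alone.

The three measured compounds share one core and differ in the groups attached to it. Compound 1 `COc1ccc(/C=C/C(=O)c2cc(-c3ccc(OC)c(OC)c3)n3nc(-c4ccccc4)cc3n2)cc1` gives 50700 nM in an ADME assay on HEK293 cells (Homo sapiens) for antiproliferative activity, read by MTT assay, with a stated time of 24 h; on this read-out higher numbers stand for weaker inhibition and lower numbers for stronger inhibition. Compound 2 `COc1ccc(-c2cc(/C=C/C(=O)c3ccc(C)cc3)nc3cc(-c4ccccc4)nn23)cc1OC` gives 62600 nM in this assay; the step of a 1.2-fold higher number from compound 1 to compound 2 (0.09 log units; within the scatter) touches a different part of the molecule than the one studied here. Compound 3 `COc1cc(-c2cc(/C=C/C(=O)c3ccccc3)nc3cc(-c4ccccc4)nn23)cc(OC)c1OC` reaches only the limit of the assay, >= 100000 nM, so its exact number is not known, as noted in the limit of >= 100000 nM in this assay, at which 1 of the 3 values shown sits. Compound 4 `COc1ccc(-c2cc(/C=C/C(=O)c3ccccc3)nc3cc(-c4ccccc4)nn23)cc1OC` differs from compound 3 by hydrogen in place of methoxy on an aromatic carbon. Among the measured compounds shown here, no measured step covers this change, so the expectation rests on the values of compounds 1 and 2 near the limit. Compound 4 is expected to show an at least 1.2-fold lower number from compound 3 to compound 4 (0.09 log units; that floor lies within the scatter), giving an estimated 80000 nM with a range of 30000 nM to 200000 nM.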

Compound 4, half-maximal inhibitory concentration: 51200 nM
The estimate for compound 4 lay 1.6-fold (0.19 log units) above the measured number, within the range that was stated.
By their numbers in this assay, from the lowest: compounds 1, 4 and 2 (each within the scatter of the next). At a limit, above all of these: compound 3.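

Replacing the methoxy with hydrogen, which turns 3,4,5-trimethoxyphenyl into 3,4-dimethoxyphenyl, yields a measured number where compound 3 has only a limit: the limit of >= 100000 nM in this assay, at which 1 of the 4 values shown sits. The change reads as an at least 1.9-fold lower number from compound 3 to compound 4 (0.29 log units; that floor lies within the scatter), so a real gain in inhibition is not established. The other two steps, a 1.2-fold lower number from compound 2 to compound 4 (0.09 log units; within the scatter) and a 1.0-fold higher number from compound 1 to compound 4 (0.00 log units; within the scatter), show that changes in a different part of the molecule also stay within the scatter.

Going by these compounds, the true size of the step from compound 3 stays open. So does the effect of an amine or a carboxylic acid at this position.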